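Thiazolyl for pyrazolyl on the salicylic core, anti-edema activity

The source may hold more compounds than are shown below. What is called first, only, known or untested is meant among the compounds shown, and "the series" means these compounds.

Compound 1 `O=C(O)c1cc(-c2cc[nH]n2)ccc1O` and compound 2 `O=C(O)c1cc(-c2ccccn2)ccc1O` share a core carrying a carboxy group and a hydroxy group, and differ in the five-membered or six-membered heteroaryl group attached to it. Both were examined in a functional assay on the whole organism for inhibition, with Rattus norvegicus as the target, read by paw edema; a lower number here means that less compound is needed, a higher number that more compound is needed for the effect. For compound 1 the result > 250 mg/kg is a limit of the assay and not a number. Compound 2 gives 200 mg/kg in this assay. Among the measured compounds shown here, no single-point step between measured compounds is on record; what the measured values show is the limit of > 250 mg/kg in this assay, at which 1 of the 2 values shown sits, with the other value in the same region. Compound 1 therefore stands at the weak end of what the assay can report, and no direction can be read from it.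

Compound 3 `O=C(O)c1cc(-c2nccs2)ccc1O` is not yet measured. It differs from compound 1 by 1,3-thiazol-2-yl in place of 1H-pyrazol-3-yl on an aromatic carbon. Compound 2 carries a heteroaryl group without a donor and still gives 200 mg/kg, so the change is expected to leave the activity in the same weak region. The step of an at least 1.2-fold lower number from compound 1 to compound 3 (0.09 log units; that floor lies within the scatter) is expected to stay within the scatter or come close to it. Compound 3 is estimated at 200 mg/kg, with a range from 100 mg/kg to 400 mg/kg, and a fair chance that this assay again returns only a limit.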

Compound 3, dose for half-maximal effect: > 250 mg/kg
Compound 3: no number, only a limit; the forecaster's own chance of this, stated with the estimate: 45%; at least 1.2-fold (0.09 log units) between middle value and limit.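

Compound 1 and compound 3 each return only a limit of the assay and not a number, so no step between them can be read: the limit of > 250 mg/kg in this assay, at which 2 of the 3 values shown sit.

Left open is how compound 1 and compound 3 truly compare in this assay, and whether 1,3-thiazol-2-yl in place of 1H-pyrazol-3-yl changes the activity at all.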